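The source may report more compounds than this note shows. Statements on the series, on what has been measured and on what is new or still open speak of the compounds shown alone.

In a functional assay on HEp-2 cells (Homo sapiens) for antiproliferative activity, read by MTT assay, with a stated time of 72 h (on this read-out higher numbers stand for weaker inhibition and lower numbers for stronger inhibition), compound 1 `O=c1cc(CSC(=S)N2CCCCC2)oc2cc(Cl)ccc12` gives 1600 nM. Compound 2 `O=c1cc(CSC(=S)N2CCCC2)oc2cc(Cl)ccc12` carries pyrrolidin-1-yl in place of piperidin-1-yl on the thiocarbonyl carbon. For compound 2 this assay reports only a limit, > 40000 nM. The step of an at least 25-fold higher number from compound 1 to compound 2 (1.39 log units; beyond the scatter) is therefore a large loss, and compound 2 stands at the limit of > 40000 nM in this assay, at which 1 of the 2 values shown sits, so its true number is not known, only its lower edge.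

Compound 3 `CC(C)N(C(=S)SCc1cc(=O)c2ccc(Cl)cc2o1)C(C)C` is not yet measured. It differs from compound 2 by diisopropylamino in place of pyrrolidin-1-yl on a thiocarbonyl carbon. Among the measured compounds shown here, only one measured step bears on this change, an at least 25-fold higher number from compound 1 to compound 2 (1.39 log units; beyond the scatter), and it shows that the group on the thiocarbonyl carbon can move the number a long way. Whether diisopropylamino behaves more like piperidin-1-yl or more like pyrrolidin-1-yl cannot be read from these two compounds, so the direction of the step is open and the expectation is wide. Compound 3 is estimated in this assay at 12000 nM, between 2000 nM and 40000 nM. The expected step of an at least 3.3-fold lower number from compound 2 to compound 3 (0.52 log units; beyond the scatter) is thus an estimate pointing toward a lower number, with a real chance that only a limit is reported again.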

Compound 3, half-maximal inhibitory concentration: 22700 nM
Beside the measured number, compound 3's estimate is 1.9-fold (0.28 log units) below it; low and high end bracket the measured number.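

With diisopropylamino on the thiocarbonyl carbon, this assay returns a measured number for compound 3 rather than a limit, so among the compounds shown a group with no ring can still give a readable result there, yet the large step, a 14-fold higher number from compound 1 to compound 3 (1.15 log units; beyond the scatter), leaves it well behind piperidin-1-yl. Against pyrrolidin-1-yl the comparison is far less firm, with the step reading an at least 1.7-fold lower number from compound 2 to compound 3 (0.24 log units; that floor lies within the scatter), so compound 3 cannot be said with confidence to improve on compound 2. The value for compound 2 is only a limit, which sets how little this step can show: the limit of > 40000 nM in this assay, at which 1 of the 3 values shown sits.

Across these three compounds, piperidin-1-yl gives the lowest number, but they do not show whether that lead would hold against a morpholin-4-yl, azepan-1-yl or dimethylamino group on the thiocarbonyl carbon. Also open, as far as these compounds go, are the true distance between compound 2 and compound 3 and whether these changes would read the same with a fluorine or a methoxy group in place of the chlorine on the shared core.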